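Swapping the amide's indole for a phenylethenyl chain

The compounds below may be only part of what the source reports. "The series", "measured", "known", "first", "only" and "open" are said of these compounds alone.

Of the compounds shown here, three sharing one core have been tested in a functional assay on HT-29 cells (Homo sapiens) for cytotoxicity, read by MTT assay, with a stated time of 72 h; on this read-out higher numbers stand for weaker inhibition and lower numbers for stronger inhibition. Compound 1 `CCc1ccc(C(=O)NC[C@H]2c3[nH]c4ccccc4c3C[C@H]3[C@H]4c5[nH]c6ccccc6c5C[C@@H]([C@H](C#N)N23)N4C)cc1` gives 3560 nM. Compound 2 `CN1[C@@H]2c3[nH]c4ccccc4c3C[C@H]1[C@H](C#N)N1[C@@H](CNC(=O)c3ccc4ccccc4n3)c3[nH]c4ccccc4c3C[C@@H]21` gives 150 nM. Compound 3 `CN1[C@@H]2c3[nH]c4ccccc4c3C[C@H]1[C@H](C#N)N1[C@@H](CNC(=O)c3cc4ccccc4[nH]3)c3[nH]c4ccccc4c3C[C@@H]21` gives 1220 nM, the second highest number of the three: the two steps leading to it are a 2.9-fold lower number from compound 1 to compound 3 (0.47 log units; beyond the scatter) and an 8.1-fold higher number from compound 2 to compound 3 (0.91 log units; beyond the scatter). The largest step seen is a 24-fold lower number from compound 1 to compound 2 (1.38 log units; beyond the scatter), so the group on the carbonyl carbon clearly matters here.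

Compound 4 `CN1[C@@H]2c3[nH]c4ccccc4c3C[C@H]1[C@H](C#N)N1[C@@H](CNC(=O)/C=C/c3ccccc3)c3[nH]c4ccccc4c3C[C@@H]21` differs from compound 3 in that (2-phenylethenyl in place of 1H-indol-2-yl on a carbonyl carbon). Among the measured compounds shown here, no measured step covers this exact exchange. The entering group, like the 4-ethylphenyl of compound 1, has no donor and no second ring, and compound 1 gave the highest number in this assay. A modestly higher number is therefore expected, with the estimated step from compound 3 to compound 4 being a 2.0-fold higher number from compound 3 to compound 4 (0.31 log units; beyond the scatter). For compound 4 the expected value in this assay is 2500 nM, with a range from 800 nM to 8000 nM.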

Compound 4, half-maximal inhibitory concentration: 1400 nM
Compound 4: middle estimate off by 1.8-fold (0.25 log units), on the high side; measured number inside the range.
By their numbers in this assay, from the lowest: compound 2; then compounds 3 and 4 (each within the scatter of the next); then compound 1.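

In this assay, the exchange on this carbonyl carbon is a small one (a 1.1-fold higher number from compound 3 to compound 4 (0.06 log units; within the scatter)), so the 1H-indol-2-yl and 2-phenylethenyl groups cannot be told apart here, although the entering group has no hydrogen-bond donor and no five-membered ring. Compound 4 still stands clear of the other two compounds (a 9.3-fold higher number from compound 2 to compound 4 (0.97 log units; beyond the scatter); a 2.5-fold lower number from compound 1 to compound 4 (0.41 log units; beyond the scatter)), which shows that a group without a donor need not sit level with the 4-ethylphenyl of compound 1. Nothing available explains why these two groups give such similar numbers.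

The compounds shown leave open what the double bond contributes, which a saturated 2-phenylethyl chain would address. Also open, from the compounds shown here alone, is how an amine or a carboxylic acid on the phenyl ring of the 2-phenylethenyl group would shift the number.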